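The source may report more compounds than this note shows. Statements on the series, on what has been measured and on what is new or still open speak of the compounds shown alone.

Compound 1 `C=C1[C@@H](O)[C@H](n2cnc3c(OC)nc(N)nc32)O[C@@H]1CO` gives 446000 nM in a functional assay on L1210 cells (Mus musculus) for inhibition; on this read-out higher numbers stand for weaker inhibition and lower numbers for stronger inhibition.
Compound 2 `C=C1[C@@H](O)[C@H](n2cnc3c(S)nc(N)nc32)O[C@@H]1CO` gives 207000 nM in this assay.
Compound 3 `C=C1[C@H](n2cnc3c(OC)nc(N)nc32)O[C@H](CO)[C@H]1O` gives 10000 nM in this assay.

Compound 2 differs from compound 1 by sulfanyl in place of methoxy on an aromatic carbon, and this change brought a 2.2-fold lower number from compound 1 to compound 2 (0.33 log units; beyond the scatter). Compound 3 is built from the same atoms as compound 1, joined differently; the difference between the two cores is not broken down here. Compound 3 stands lowest of the three numbers.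

Compound 4 `C=C1[C@H](n2cnc3c(S)nc(N)nc32)O[C@H](CO)[C@H]1O` has not yet been measured in this assay. Among the measured compounds shown here, it differs from compound 3 by sulfanyl in place of methoxy on an aromatic carbon, the same change at the same place as the one seen between compound 1 and compound 2. On the strength of a 2.2-fold lower number from compound 1 to compound 2 (0.33 log units; beyond the scatter), compound 4 is expected to show a 2.0-fold lower number from compound 3 to compound 4 (0.30 log units; within the scatter). Compound 4 is therefore estimated at 5000 nM, most likely between 2000 nM and 15000 nM.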

Compound 4, half-maximal inhibitory concentration: 20000 nM
Compound 4: middle estimate off by 4.0-fold (0.60 log units), on the low side; measured number outside the range, above it.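

In this assay, sulfanyl in place of methoxy on an aromatic carbon gives a 2.0-fold higher number from compound 3 to compound 4 (0.30 log units; within the scatter), and this step does not match the one on the core of compound 1: the same change on two cores in this assay, a 2.2-fold lower number (0.33 log units; beyond the scatter) from compound 1 to compound 2 and a 2.0-fold higher number (0.30 log units; within the scatter) from compound 3 to compound 4, 4.3-fold (0.63 log units) apart, beyond the scatter of two such steps

So, for this pair of cores, the step measured on one core does not transfer to the other. This does not explain why the two cores part, and with a single pair on each core it shows no general rule; the step on the core of compound 3 also stays within the scatter by itself.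

The compounds shown leave open how an amine or an ethoxy group on the same aromatic carbon would behave on the two cores. They also leave open whether either group would separate the cores as sulfanyl and methoxy do.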